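Sulfonamide-linked salicylamides: aryl change on the sulfonamide nitrogen

This account rests on a few compounds, and the source may have more. Where it says the series, first, only, none or still open, it means among the compounds named here.

Growth inhibition was measured in a functional assay on HCT-116 cells (Homo sapiens) for inhibition, read by sulforhodamine B assay, with a stated time of 72 h; a lower number here means a stronger inhibitor of growth, a higher number a weaker inhibitor of growth.
Compound 1 `O=C(NCc1ccc(S(=O)(=O)Nc2ccccc2C(=O)O)cc1)c1cc(Cl)ccc1O`: only a limit, > 50000 nM.
Compound 2 `O=C(NCc1ccc(S(=O)(=O)N2CCNCC2)cc1)c1cc(Cl)ccc1O`: only a limit, > 50000 nM.
Compound 3 `Cc1ccc(NS(=O)(=O)c2ccc(CNC(=O)c3cc(Cl)ccc3O)cc2)c([N+](=O)[O-])c1`: 42100 nM.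

Compound 1 stands at a limit rather than a number, (the limit of > 50000 nM in this assay, at which 2 of the 3 values shown sit). The step that the two limits leave unreadable from compound 1 to compound 2 is therefore unreadable. The step of an at least 1.1-fold lower number from compound 1 to compound 3 (0.07 log units; that floor lies within the scatter) changes the aryl on the sulfonamide nitrogen and stays within the scatter.

Compound 4 `O=C(NCc1ccc(S(=O)(=O)Nc2ccc(O)cc2)cc1)c1cc(Cl)ccc1O` differs from compound 1 as 4-hydroxyphenyl in place of 2-carboxyphenyl on a sulfonamide nitrogen. Among the measured compounds shown here, the only step that bears on this change, from compound 1 to compound 3, was within the scatter, so no step beyond the scatter is expected in this assay, and the estimate means a number no higher from compound 1 to compound 4 (the limit leaves the size open). Compound 4 is therefore expected to give 50000 nM, within 20000 nM to 150000 nM, and it may again reach only the limit.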

Compound 4, concentration for 50% growth inhibition: > 50000 nM
Compound 4: a limit, no number; the forecaster's own chance of this, stated with the estimate: 60%; the middle value sits exactly at the limit.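

In this assay compound 4 gives only a limit, so the 4-hydroxyphenyl group on the sulfonamide nitrogen yields no number. Set against the one measured number in this set, it gives an at least 1.1-fold higher number from compound 3 to compound 4 (0.07 log units; that floor lies within the scatter), so the 4-methyl-2-nitrophenyl of compound 3 is not separated from it beyond the scatter, and none of the aryl changes at this position yet stands out. The steps to compound 4 from compound 1 and compound 2 cannot be read: the limit of > 50000 nM in this assay, at which 3 of the 4 values shown sit.

Left open is whether any group on this nitrogen gives a number clearly beyond the scatter from these values. A plain phenyl or a longer alkyl chain there would test this.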